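The source may report more compounds than this note shows. Statements on the series, on what has been measured and on what is new or still open speak of the compounds shown alone.

Of the compounds shown here, two have been measured in an assay on cell membranes for binding affinity to Adrenergic receptor alpha-1 (Rattus norvegicus), read by radioligand binding; a lower number here means a stronger inhibitor, a higher number a weaker inhibitor. Compound 1 `CCOc1ccccc1N1CCN(CCCCCCCn2ncc(N3CCN(C(=O)c4ccco4)CC3)c(Cl)c2=O)CC1` gives 0.5 nM in this assay. Compound 2 `CCOc1ccccc1N1CCN(CCCCCCCn2ncc(Cl)c(N3CCN(C(=O)c4ccco4)CC3)c2=O)CC1` gives 0.23 nM in this assay; of the two numbers it is the lower, and the gap to compound 1 lies beyond the usual scatter, so compound 2 is the stronger binder of the pair.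

Compound 3 `CC(C)Oc1ccccc1N1CCN(CCCCCCCn2ncc(Cl)c(N3CCN(C(=O)c4ccco4)CC3)c2=O)CC1` is the next compound to be tested. It differs from compound 2 in one place: methyl in place of hydrogen on a saturated chain carbon bound to an oxygen on an aromatic ring and a saturated chain carbon. Going by the values given here, no measured pair shows this change, so its effect is unknown. The change is small and leaves the rest of the shared core untouched; the step is expected to be slight, possibly none beyond the scatter, with a mild drift toward a higher number as the more likely direction. Compound 3 is therefore estimated at 0.4 nM in this assay, within 0.12 nM to 1.3 nM, a step of a 1.7-fold higher number from compound 2 to compound 3 (0.24 log units; within the scatter).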

Compound 3, inhibition constant: 0.08 nM
Compound 3: middle estimate off by 5.0-fold (0.70 log units), on the high side; measured number outside the range, below it.
By their numbers in this assay, from the lowest: compound 3; then compound 2; then compound 1.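

In this assay, the change from ethoxy to isopropoxy brings a 2.9-fold lower number from compound 2 to compound 3 (0.46 log units; beyond the scatter). Going by these compounds alone, this is the first reading at this position, since compound 1 and compound 2 both carry the ethoxy group and differ elsewhere; it shows that the saturated chain carbon bound to the oxygen takes a methyl and that the number falls beyond the scatter rather than staying level or rising. The data offer no measurement that accounts for this step.

The compounds shown leave open whether the number keeps falling with a tert-butyl or cyclopentyl group on this oxygen, or rises again with a smaller methoxy group. They also leave open whether isopropoxy brings a similar step on the core of compound 1, as this single step comes from the core of compound 2 alone.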